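A few compounds are considered here, and "the series" means these few. Any claim that something is new, unique, unknown or untested is made for them only; others in the source may bear on it.

Two compounds in this set carry numbers. Compound 1 `N=C(N)c1ccc(-c2ccc(-c3cncc4ccccc34)s2)s1` gives 1700 nM in a functional assay on HOP-62 cells (Homo sapiens) for inhibition, read by sulforhodamine B assay, with a stated time of 48 h; a higher number here means a weaker inhibitor of growth, a lower number a stronger inhibitor of growth. Compound 2 `N=C(N)c1ccc(-c2ccc(-c3ccc(F)cc3)o2)o1` gives 1600 nM in this assay. Of the two numbers, that of compound 2 is the lower one, but its nearest neighbour, compound 1, sits within the scatter of it, so the two compounds cannot be set in any order on this evidence.

Compound 3 `N=C(N)c1ccc(-c2ccc(-c3ccc(Cl)cc3)o2)o1` differs from compound 2 in a single place: chloro in place of fluoro on an aromatic carbon, para to a large group. Among the compounds with values here, no pair among the measured compounds differs in just this way, so there is no measured step to lean on. With nothing else to go by, the step in this assay is expected to be small, within the scatter or only a little beyond it, and if it leans anywhere, toward a lower number.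

For compound 3 the estimate in this assay is 1300 nM, with a range from 500 nM to 3500 nM. That estimate amounts to an expected 1.2-fold lower number from compound 2 to compound 3 (0.09 log units; within the scatter).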

Compound 3, concentration for 50% growth inhibition: 1650 nM
For compound 3 the middle estimate is 1.3-fold (0.10 log units) below the measured one, within the range that was stated.
By their numbers in this assay, from the lowest: compounds 2, 3 and 1 (each within the scatter of the next).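

Swapping fluoro for chloro on an aromatic carbon, para to a large group, gives the first measured step at this position in this assay, and that step is a 1.0-fold higher number from compound 2 to compound 3 (0.01 log units; within the scatter), so the two halogens cannot be set in any order here. Where the earlier compounds offered no pair differing in one place, this pair shows that the shared core can carry either chloro or fluoro at this position with no readable difference in growth inhibition, although this rests on a single exchange and supports no wider rule about halogens. Nothing available explains why the two compounds stand level, and no measured property of either group bears on this result.

The compounds shown leave open whether a group other than a halogen at the same place, such as an amine, a carboxylic acid or a methoxy group, would move the number beyond the scatter. They also leave open whether the same exchange would stay as small on a core other than that of compound 2.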